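This account rests on a few compounds, and the source may have more. Where it says the series, first, only, none or still open, it means among the compounds named here.

The compounds share one core, carrying a nitrile group and a sulfur-linked side chain, as in compound 1 `C#CCSc1nc(Nc2cccc(C(F)(F)F)c2)c(C#N)c(-c2ccccc2)n1`, compound 2 `C#CCSc1nc(Nc2ccc(Cl)cc2)c(C#N)c(-c2ccccc2)n1` and compound 3 `N#Cc1c(Nc2cccc(C(F)(F)F)c2)nc(SCc2cn(Cc3ccccc3Cl)nn2)nc1-c1ccccc1`. In a functional assay on MCF7 cells (Homo sapiens) for inhibition, read by MTT assay, with a stated time of 72 h (on this read-out lower numbers stand for stronger inhibition and higher numbers for weaker inhibition), compound 1 gives only a limit of the assay, > 128000 nM. Compound 2 likewise reaches only a limit, > 128000 nM. Among the compounds with values here, compound 3, whose side chain is longer than in the other two, gives 12600 nM in this assay, the only number in the set. The remaining two values sit at the limit of > 128000 nM in this assay, at which 2 of the 3 values shown sit. Compound 4 `COc1ccccc1Nc1nc(SCc2cn(Cc3ccccc3Cl)nn2)nc(-c2ccccc2)c1C#N` keeps the side chain of compound 3 and differs from it in one place: 2-methoxyphenyl in place of 3-(trifluoromethyl)phenyl on a nitrogen on an aromatic ring. Within the data shown here, no measured pair isolates this change, so its effect can be judged only from the single value of compound 3. The step of a 1.6-fold higher number from compound 3 to compound 4 (0.20 log units; within the scatter) is expected to lie within or slightly beyond the scatter, with a modest chance of a weaker result. Compound 4 is therefore estimated at 20000 nM in this assay, with a range from 5000 nM to 80000 nM.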

Compound 4, half-maximal inhibitory concentration: 6170 nM
The estimate for compound 4 lay 3.2-fold (0.51 log units) above the measured number; measured number inside the range.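

In this assay, replacing 3-(trifluoromethyl)phenyl with 2-methoxyphenyl on the nitrogen gives a 2.0-fold lower number from compound 3 to compound 4 (0.31 log units; beyond the scatter). Within the data shown here, this is the first readable effect of a change at this place: compound 1 and compound 2 also differ in the group on this nitrogen, but both stand at a limit of the assay, so they offered no step to read. With the side chain of compound 3 in place, the group on this nitrogen can therefore shift the number modestly toward stronger inhibition, though nothing given here bears on why.

The compounds shown leave open whether the same exchange would have any readable effect with the side chain of compound 1. They also leave open how a hydroxy group, an amine or a carboxylic acid in place of the methoxy group would fare on this phenyl ring.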